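This account rests on a few compounds, and the source may have more. Where it says the series, first, only, none or still open, it means among the compounds named here.

In a functional assay on LoVo cells (Homo sapiens) for cytotoxicity, read by MTT assay, with a stated time of 72 h (a lower number here means a stronger inhibitor, a higher number a weaker inhibitor), compound 1 `COc1ccc2[nH]c(-c3ccc[nH]3)c(C3CC(=O)NC3=O)c2c1` gives 4000 nM and compound 2 `O=C1CC(c2c(-c3ccc[nH]3)[nH]c3ccccc23)C(=O)N1` gives 8000 nM. Within the data shown here, these are the only two numbers so far, so compound 2 has a single neighbour, and the two lie within the scatter of each other. Compound 3 `Cc1ccc2[nH]c(-c3ccc[nH]3)c(C3CC(=O)NC3=O)c2c1` differs from compound 2 by methyl in place of hydrogen on an aromatic carbon. Among the measured compounds shown here, the one measured step that bears on this change swaps hydrogen for methoxy on an aromatic carbon: a 2.0-fold higher number from compound 1 to compound 2 (0.30 log units; within the scatter). A change of that kind has so far moved this assay by no more than the scatter, so none beyond it is expected here. The expected step is a 1.3-fold lower number from compound 2 to compound 3 (0.12 log units; within the scatter). Compound 3 is estimated at 6000 nM, with an expected range of 2500 nM to 14000 nM.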

Compound 3, half-maximal inhibitory concentration: 4000 nM
For compound 3 the middle estimate is 1.5-fold (0.18 log units) above the measured one, and the stated range covers the measured number.
By their numbers in this assay, from the lowest: compounds 1, 3 and 2 (each within the scatter of the next).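

In this assay methyl in place of hydrogen on this aromatic carbon gives a 2.0-fold lower number from compound 2 to compound 3 (0.30 log units; within the scatter) and methyl in place of methoxy gives no change at the digits printed from compound 1 to compound 3 (within the scatter) at the same position. Methyl thus joins methoxy as a second group here that stays within the scatter of hydrogen, so compounds 1, 2 and 3 cannot be ranked. Going by these compounds, whether an amine, a carboxylic acid or a longer chain at this position would move the number beyond the scatter remains open. Nothing available speaks to a cause for these numbers.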